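A few compounds are considered here, and "the series" means these few. Any claim that something is new, unique, unknown or untested is made for them only; others in the source may bear on it.

Compound 1 `COc1ccc(-c2cn(C[C@H]3COC(C)(C)O3)nn2)cc1` — in a functional assay on B16 cells (Mus musculus) for cytotoxicity, read by MTT assay, with a stated time of 48 h (on this read-out higher numbers stand for weaker inhibition and lower numbers for stronger inhibition), compound 1 gives > 100000 nM, which is a limit of the assay and not a number.
Compound 2 `Cc1cccc(-c2cn(C[C@H]3COC(C)(C)O3)nn2)c1` — in this assay compound 2 gives > 100000 nM, again a limit and not a number.
Compound 3 `COc1cccc(Cn2cc(-c3ccc(C(F)(F)F)cc3)nn2)c1` — in this assay compound 3 gives 17400 nM.

Going by the values given here, compound 1 therefore stands on a limit: this assay reports no number for it, only that its value lies beyond the range measured. Of the three values shown, two sit at the limit of > 100000 nM in this assay, at which 2 of the 3 values shown sit, and only compound 3 gives a number at all. No two of these compounds differ in just one place, so no single measured step exists to show how a change at one spot moves the read-out.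

Compound 4 `CC1(C)OC[C@H](Cn2cc(-c3ccc([N+](=O)[O-])cc3)nn2)O1` is obtained from compound 1 by nitro in place of methoxy on an aromatic carbon, in words, nitro in place of methoxy on an aromatic carbon. Because compound 1 gives > 100000 nM, a limit, the size of the step cannot be counted from the data, and the expectation is that the step from compound 1 to compound 4 is none beyond the scatter, so an at least 1.2-fold lower number from compound 1 to compound 4 (0.09 log units; that floor lies within the scatter) is expected to be small. Compound 4 is estimated to give 80000 nM in this assay, within a range from 20000 nM to 300000 nM, with a real chance that only a limit is reported.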

Compound 4, half-maximal inhibitory concentration: > 100000 nM
Compound 4: a limit, no number; the forecaster's own chance of this, stated with the estimate: 55%; middle value at least 1.2-fold (0.09 log units) from the limit.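

In this assay compound 4 gives > 100000 nM, a limit and not a number. Compound 1 stands on a limit as well, so no step can be read between compound 1 and compound 4: the limit of > 100000 nM in this assay, at which 3 of the 4 values shown sit.

The compounds shown leave open whether nitro in place of methoxy on an aromatic carbon moves the read-out at all.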